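A Pentyl Carbamate in Place of a Benzyl Carbamate

The source may hold more compounds than are shown below. What is called first, only, known or untested is meant among the compounds shown, and "the series" means these compounds.

Compound 2 `C[C@@H]1CN(C(=O)c2nc(Nc3cc(C4CC4)[nH]n3)c3cc(Cl)ccc3n2)CCN1C(=O)OCc1ccccc1` was tested in an assay for inhibition of serine/threonine-protein kinase PAK 4 (Homo sapiens), read by FRET and Z'-LYTE, with a stated time of 60 min, tested at 50 uM, in the presence of a further agent that is not named here (on this read-out lower numbers stand for a weaker effect and higher numbers for a stronger effect at the one concentration tested), where compound 2 gives 96%. Among the compounds with values here, the only other number measured comes from compound 1 `CC(C)C(=O)OCOC(=O)N1CCN(C(=O)c2nc(Nc3cc(C4CC4)[nH]n3)c3cc(Cl)ccc3n2)C[C@H]1C`, which in this assay gives 86.9%; the step of a number 9.1 percentage points higher from compound 1 to compound 2 (within the scatter) lies within the scatter, so on this read-out the two compounds cannot be told apart. Compound 3 `CCCCCOC(=O)N1CCN(C(=O)c2nc(Nc3cc(C4CC4)[nH]n3)c3cc(Cl)ccc3n2)C[C@H]1C` is a further variation at the same place: butyl in place of phenyl on a saturated chain carbon bound to an oxygen next to a carbonyl group. Within the data shown here, the one measured step that bears on this change is a number 9.1 percentage points higher from compound 1 to compound 2 (within the scatter), which also exchanged the group on a saturated chain carbon bound to an oxygen next to a carbonyl group and stayed within the scatter. Among the measured compounds shown here, no measured compound carries a butyl group at that place, so there is no direct precedent for it. With only a within-scatter precedent for changing this group, the expected step is a number 6 percentage points lower from compound 2 to compound 3 (within the scatter), small and in no clear direction. Compound 3 is therefore estimated at 90%, with a range from 75% to 98%.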

Compound 3, a percentage reported as inhibition, at one concentration (the size of the read-out at that concentration, not a potency): 32.7%
The estimate for compound 3 lay 57.3 percentage points above the measured number; the whole stated range lies above it.
By their numbers in this assay, from the lowest: compound 3; then compounds 1 and 2 (each within the scatter of the next).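

The group on the saturated chain carbon bound to an oxygen next to a carbonyl group clearly matters in this assay: butyl in place of phenyl means a number 63.3 percentage points lower from compound 2 to compound 3 (beyond the scatter), and butyl in place of (isopropylcarbonyl)oxy means a number 54.2 percentage points lower from compound 1 to compound 3 (beyond the scatter). The earlier pair, whose numbers could not be told apart, made this place look tolerant, but it does not accept every group, and the aromatic ring alone does not separate the compounds: compound 1 has no ring in this group, yet it stands with compound 2 and far from compound 3. Nothing at hand explains why the pentyl carbamate behaves so differently from the other two compounds.

Going by these compounds, whether the ester in compound 1 and the aromatic ring in compound 2 have anything in common that butyl lacks stays open, and so does the role of chain length. A cyclohexyl group at this place would test a ring without aromaticity, while an ethyl or octyl group would show how the number moves with a shorter or longer chain.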